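The source may hold more compounds than are shown below. What is called first, only, known or untested is meant among the compounds shown, and "the series" means these compounds.

The shared core carries a sulfanyl substituent that is varied across the set. Compound 1 `Cc1cc(N2CC[C@@H](C)[C@@H](N(C)c3ncnc4[nH]ccc34)C2)n2nc(SCc3cc(Cl)ccc3Cl)nc2n1` gives 18900 nM in a functional assay on BGC-823 cells (Homo sapiens) for inhibition, read by MTT assay, with a stated time of 72 h; on this read-out higher numbers stand for weaker inhibition and lower numbers for stronger inhibition. Compound 2 `Cc1cc(N2CC[C@@H](C)[C@@H](N(C)c3ncnc4[nH]ccc34)C2)n2nc(SCc3ccc([N+](=O)[O-])cc3)nc2n1` gives 59600 nM in this assay, and the step between them is a 3.2-fold higher number from compound 1 to compound 2 (0.50 log units; beyond the scatter). Compound 3 `Cc1cc(N2CC[C@@H](C)[C@@H](N(C)c3ncnc4[nH]ccc34)C2)n2nc(SCCCc3ccccc3)nc2n1` returns only a limit in this assay, > 100000 nM. From this follow the steps of an at least 5.2-fold higher number from compound 1 to compound 3 (0.72 log units; beyond the scatter) and an at least 1.6-fold higher number from compound 2 to compound 3 (0.22 log units; that floor lies within the scatter); the floor of both rests on (the limit of > 100000 nM in this assay, at which 1 of the 3 values shown sits). Compound 3 thus stands at the weak end of the numbers shown, without a number of its own.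

Compound 4 `C#CSc1nc2nc(C)cc(N3CC[C@@H](C)[C@@H](N(C)c4ncnc5[nH]ccc45)C3)n2n1` differs from compound 3 by ethynyl in place of 3-phenylpropyl on a sulfur. Going by the values given here, none of the measured steps exchanges an arylalkyl group for a short chain without a ring; each of the three swaps one aryl group for another, and each either raised the number or stayed within the scatter. Among the compounds with values here, no measured step therefore bears directly on this change, and no direction beyond the scatter can be argued from them. The expectation for compound 4 is a number near the weak end, 80000 nM with a range of 20000 nM to 300000 nM. The step this estimate implies, an at least 1.2-fold lower number from compound 3 to compound 4 (0.09 log units; that floor lies within the scatter), is expected to stay within the scatter.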

Compound 4, half-maximal inhibitory concentration: 62100 nM
The estimate for compound 4 lay 1.3-fold (0.11 log units) above the measured number; the measured number falls inside the stated range.
By their numbers in this assay, from the lowest: compound 1; then compounds 2 and 4 (each within the scatter of the next). At a limit, above all of these: compound 3.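

In this assay, a group with no ring on this sulfur gives a measured number level with 4-nitrobenzyl: a 1.0-fold higher number from compound 2 to compound 4 (0.02 log units; within the scatter). Among the compounds with a number, only compound 1, with its 2,5-dichlorobenzyl group, stands apart from ethynyl: a 3.3-fold higher number from compound 1 to compound 4 (0.52 log units; beyond the scatter). Against 3-phenylpropyl, the comparison yields only an at least 1.6-fold lower number from compound 3 to compound 4 (0.20 log units; that floor lies within the scatter), and this floor rests on a limit: the limit of > 100000 nM in this assay, at which 1 of the 4 values shown sits.

On these data alone, whether a plain benzyl group keeps the number of compound 1, 18900 nM, or loses it without the two chlorine atoms remains open. Also open, as far as these compounds go, is whether an amine, a carboxylic acid or a longer chain without a ring on this sulfur would shift the number beyond the scatter from that of compound 4.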